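This account rests on a few compounds, and the source may have more. Where it says the series, first, only, none or still open, it means among the compounds named here.

Compound 1, with the structure `Cc1cccc(NC(=S)N/N=C/c2ccc3ccccc3n2)c1`, was tested in a functional assay on HeLa cells (Homo sapiens) for antiproliferative activity, read by sulforhodamine B assay, with a stated time of 72 h; a lower number here means a stronger inhibitor, a higher number a weaker inhibitor. In this assay compound 1 reaches only the limit of > 100000 nM, so no number is known for it. A second compound, compound 2, has the structure `NC(=S)N/N=C/c1cnc2ccccc2n1`. In this assay compound 2 likewise stops at the limit of > 100000 nM. Within the data shown here, compound 1 therefore stands at the limit of > 100000 nM in this assay, at which 2 of the 2 values shown sit, and nothing measured so far separates it from compound 2.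

The next compound, compound 3, has the structure `COc1ccc(NC(=S)N/N=C/c2ccc3ccccc3n2)cc1`. It differs from compound 1 by 4-methoxyphenyl in place of 3-methylphenyl on an amide-type nitrogen. Among the measured compounds shown here, no measured pair differing in one place is available to show how large a step such a change gives in this assay, and both known values are limits, so the expected step from compound 1 is none beyond the usual scatter, with compound 3 most likely remaining at the limit as well. The expected step is therefore a step that the limit leaves unreadable from compound 1 to compound 3. For compound 3 the estimate in this assay is 150000 nM, with a range from 50000 nM to 500000 nM.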

Compound 3, half-maximal inhibitory concentration: 72600 nM
Estimate against measurement, compound 3: 2.1-fold (0.32 log units) above, and the stated range covers the measured number.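

In this assay compound 3 is the first compound shown to give a number rather than a limit, 72600 nM, so this position on the amide-type nitrogen can carry a group that brings the reading within the range of the assay. Going by these compounds, putting 4-methoxyphenyl in place of 3-methylphenyl gives an at least 1.3-fold lower number from compound 1 to compound 3 (0.13 log units; that floor lies within the scatter), and this figure is only a floor, so the true size of the step remains unknown and could be either small or much larger. Compound 1 remains a limit and not a number, and that limit still describes most of what is shown: the limit of > 100000 nM in this assay, at which 2 of the 3 values shown sit.

The change alters both the group on the phenyl ring and the place it occupies there, so the compounds shown do not tell whether the methoxy group itself or its place accounts for the numerical reading of compound 3. On these data alone, how a 3-methoxyphenyl or 4-methylphenyl group would read at this nitrogen stays open, as does the reading of a phenyl ring carrying an amine or a carboxylic acid.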